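Replacing the amide aryl group: compound 3 to compound 4

The source may report more compounds than this note shows. Statements on the series, on what has been measured and on what is new or still open speak of the compounds shown alone.

Measured compounds:
compound 1, `COc1ccc(-n2nc(C(N)=O)nc2-c2cc(OC)c(OC)c(OC)c2)cc1`, 92%
compound 2, `COc1ccc(NC(=O)c2nc(-c3cc(OC)c(OC)c(OC)c3)n(-c3ccc(OC)cc3)n2)cc1`, 86%
compound 3, `COc1ccc(-n2nc(C(=O)Nc3ccccc3OC)nc2-c2cc(OC)c(OC)c(OC)c2)cc1`, 38%

The three measured compounds share one core and differ only in what sits on an amide-type nitrogen. In a functional assay on the whole organism for inhibition, with Rattus norvegicus as the target, read by paw edema, with stated times of 30 min and 3 h, at a dose of 0.28 mmol/kg by the oral route (a higher number here means more inhibition at the dose given (going by the name of the read-out), a lower number less inhibition), compound 1 gives 92%. Compound 2 gives 86%. Compound 3 gives 38% and stands lowest of the three: the step of a number 54 percentage points lower from compound 1 to compound 3 (beyond the scatter) and the step of a number 48 percentage points lower from compound 2 to compound 3 (beyond the scatter) are both large, whereas the step of a number 6 percentage points lower from compound 1 to compound 2 (within the scatter) is small.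

Compound 4, `COc1ccc(-n2nc(C(=O)Nc3cccc(F)c3)nc2-c2cc(OC)c(OC)c(OC)c2)cc1`, differs from compound 3 in one place: 3-fluorophenyl in place of 2-methoxyphenyl on an amide-type nitrogen. For the measured compounds named here, no measured step involves a 3-fluorophenyl, so the new group itself is untested. Going by the values given here, what the measured steps do show is that the 2-methoxyphenyl is the one group associated with the low number, while hydrogen and 4-methoxyphenyl give similar high numbers. Compound 4 is therefore expected to lie above compound 3, with a step of a number 24 percentage points higher from compound 3 to compound 4 (beyond the scatter) in this assay. Among the compounds with values here, the estimate for compound 4 is 62%, within a range from 32% to 88%, the wide range reflecting that no measured compound carries the entering group.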

Compound 4, a percentage reported as inhibition, in the whole organism at one dose (the size of the read-out at that dose, not a potency): 92%
For compound 4 the middle estimate is 30 percentage points below the measured one; the measured number lies above the stated range.
By their numbers in this assay, from the lowest: compound 3; then compounds 2, 1 and 4 (each within the scatter of the next).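

At this amide-type nitrogen, a second substituted phenyl group now holds the high number in this assay: 3-fluorophenyl in place of 2-methoxyphenyl gives a number 54 percentage points higher from compound 3 to compound 4 (beyond the scatter), and the comparisons with the other two compounds give a number 6 percentage points higher from compound 2 to compound 4 (within the scatter) and no change at the digits printed from compound 1 to compound 4 (within the scatter). Among these four compounds only compound 3 stands apart, so the low number goes with the 2-methoxyphenyl and not with a phenyl group on this nitrogen as such. Nothing available here speaks to what lies behind this difference.

The compounds shown leave open whether a 2-fluorophenyl would also give a low number or a 3-methoxyphenyl a high one. They also leave open how a non-aromatic group on this nitrogen, such as a cyclohexyl or a longer alkyl chain, would compare.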